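Swapping the pyridyl ring on a hydroxamic acid scaffold

The compounds below may be only part of what the source reports. "The series", "measured", "known", "first", "only" and "open" are said of these compounds alone.

Compound 1 `O=C(NO)c1cccc(/C=C/c2ccnc(-c3cc(F)ccc3O)c2)c1`, compound 2 `O=C(NO)c1ccc(/C=C/c2ccnc(-c3ccccc3O)c2)cc1` and compound 3 `O=C(NO)c1ccc(/C=C/c2ccnc(-c3cccnc3)c2)cc1` share a hydroxamic acid linked through a double bond to the same core and differ only in the aromatic ring attached to that core. In a functional assay on HCT-116 cells (Homo sapiens) for antiproliferative activity, read by CellTiter-Glo, with a stated time of 72 h (on this read-out lower numbers stand for stronger inhibition and higher numbers for weaker inhibition), compound 1 gives 3890 nM, compound 2 gives 1450 nM and compound 3 gives 5140 nM. Among these three numbers compound 3 stands highest; its gap to compound 1 lies within the scatter, whereas the step of a 3.5-fold higher number from compound 2 to compound 3 (0.55 log units; beyond the scatter) is beyond it. Compound 4 `COc1ccc(-c2cc(/C=C/c3ccc(C(=O)NO)cc3)ccn2)cc1` has not yet been measured. It differs from compound 3 in one place: 4-methoxyphenyl in place of pyridin-3-yl on an aromatic carbon. For the measured compounds named here, the single measured step that bears on this change is a 3.5-fold higher number from compound 2 to compound 3 (0.55 log units; beyond the scatter), where pyridin-3-yl entered in place of a carbon-only ring and the number rose modestly. In compound 4 pyridin-3-yl leaves again and a carbon-only ring with one hydrogen-bond acceptor enters, so a modest step toward a lower number is expected, tempered because 4-methoxyphenyl is not the 2-hydroxyphenyl of compound 2 with its 1450 nM. Compound 4 is therefore estimated at about 2500 nM, within a range from 1000 nM to 6500 nM. This estimate corresponds to an expected step of a 2.1-fold lower number from compound 3 to compound 4 (0.31 log units; beyond the scatter) in this assay.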

Compound 4, half-maximal inhibitory concentration: 3560 nM
Estimate against measurement, compound 4: 1.4-fold (0.15 log units) below, within the range that was stated.
By their numbers in this assay, from the lowest: compound 2; then compounds 4, 1 and 3 (each within the scatter of the next).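

In this assay, the position next to the ring nitrogen of the shared core now carries two different six-membered aromatic rings, pyridin-3-yl and 4-methoxyphenyl, and the exchange gives a 1.4-fold lower number from compound 3 to compound 4 (0.16 log units; within the scatter), so replacing the ring nitrogen of the substituent with a carbon-only ring bearing a methoxy group does not by itself separate the two compounds. The comparison between the two carbon-only rings gives a 2.5-fold higher number from compound 2 to compound 4 (0.39 log units; beyond the scatter), which shows that the lower number of compound 2 does not extend to every carbon-only ring at this position and depends on which carbon-only ring is present. No supporting measurement bears on why these rings rank as they do.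

The compounds shown change the kind of substituent and its place on the ring together, so they leave open whether the hydroxyl group of 2-hydroxyphenyl or its location accounts for the step between these two compounds. They also leave open how an amine or a carboxylic acid on the carbon-only ring would read in this assay.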